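The source may hold more compounds than are shown below. What is called first, only, known or untested is meant among the compounds shown, and "the series" means these compounds.

The three measured compounds, all sharing one core, are:

Compound 1, `CC(C)NC(=S)N/N=C1\CC(c2ccc(O)cc2)Oc2cc(O)ccc21`, 38200 nM in a functional assay on HCT-116 cells (Homo sapiens) for cytotoxicity, read by MTT assay, with a stated time of 72 h; a lower number here means a stronger inhibitor, a higher number a weaker inhibitor.
Compound 2, `CCCNC(=S)N/N=C1\CC(c2ccc(O)cc2)Oc2cc(O)ccc21`, 54000 nM in this assay.
Compound 3, `CCCN(CCC)C(=S)N/N=C1\CC(c2ccc(O)cc2)Oc2cc(O)ccc21`, 41900 nM in this assay.

Compound 2 gives the highest of the three numbers, but its steps to both neighbours are small: a 1.4-fold higher number from compound 1 to compound 2 (0.15 log units; within the scatter) and a 1.3-fold lower number from compound 2 to compound 3 (0.11 log units; within the scatter), both within the scatter. The three compounds therefore cannot be ordered against one another on these numbers.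

Compound 4, `CC(C)(C)NC(=S)N/N=C1\CC(c2ccc(O)cc2)Oc2cc(O)ccc21`, has not yet been measured in this assay. It differs from compound 2 in one place: tert-butyl in place of propyl on an amide-type nitrogen.

The step that bears most directly on this change is a 1.4-fold higher number from compound 1 to compound 2 (0.15 log units; within the scatter), which swaps one three-carbon group for another on the same amide-type nitrogen and stays within the scatter. The other two steps, a 1.1-fold higher number from compound 1 to compound 3 (0.04 log units; within the scatter) and a 1.3-fold lower number from compound 2 to compound 3 (0.11 log units; within the scatter), change the substitution on that nitrogen more thoroughly and again stay within the scatter. Every variation tried so far on this nitrogen has left the number essentially unchanged, so compound 4 is expected to land close to compound 2, with no step beyond the scatter; the expected step is a 1.2-fold lower number from compound 2 to compound 4 (0.09 log units; within the scatter).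

Compound 4 is estimated at 44000 nM, within a range from 20000 nM to 95000 nM.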

Compound 4, half-maximal inhibitory concentration: 25900 nM
Estimate against measurement, compound 4: 1.7-fold (0.23 log units) above, and the stated range covers the measured number.
By their numbers in this assay, from the lowest: compounds 4, 1, 3 and 2 (each within the scatter of the next, the first and the last beyond it).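

On the amide-type nitrogen whose other neighbour is the thiocarbonyl carbon, tert-butyl in place of propyl gives a 2.1-fold lower number from compound 2 to compound 4 (0.32 log units; beyond the scatter) in this assay, the only step among these compounds to pass the scatter, and it does so modestly. This shows that the number at this position can respond to the group carried there, though the response so far is small and appears only between the two ends of the series, while the neighbouring steps, a 1.5-fold lower number from compound 1 to compound 4 (0.17 log units; within the scatter) and a 1.6-fold lower number from compound 3 to compound 4 (0.21 log units; within the scatter), stay within the scatter, so compound 4 cannot be set apart from compound 1 or compound 3. No measured information on the compounds offers an account of this step.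

Going by these compounds, whether a ring on this nitrogen, such as cyclohexyl or phenyl, would take the number beyond that of compound 4 remains open, as does what a methyl group there would give. On these data alone, all of these numbers also come from a single cell line, so how this change would read on other cells stays unknown.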